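This account rests on a few compounds, and the source may have more. Where it says the series, first, only, none or still open, it means among the compounds named here.

Measured so far:
compound 1 `CC(Cl)CC(=O)NC1=C(C#N)C(c2ccc(Cl)cc2Cl)C2=C(CCCC2=O)N1c1ccc(S(N)(=O)=O)cc1`, 20%
compound 2 `N#CC1=C(NC(=O)c2ccccc2)N(c2ccc(S(N)(=O)=O)cc2)C2=C(C(=O)CCC2)C1c1ccc(Cl)cc1Cl`, 50%

Both were tested in a functional assay on Ehrlich cells (Mus musculus) for cytotoxicity, read by trypan blue exclusion, with a stated time of 2 h, tested at 10 ug/mL; on this read-out higher numbers stand for a stronger effect at the one concentration tested and lower numbers for a weaker effect. Compound 1 stands lowest of the two numbers; its nearest neighbour is compound 2, the step being a number 30 percentage points higher from compound 1 to compound 2 (beyond the scatter). That step exchanges the group on the carbonyl carbon while the amide itself is kept.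

Compound 3 `CCO/C=N/C1=C(C#N)C(c2ccc(Cl)cc2Cl)C2=C(CCCC2=O)N1c1ccc(S(N)(=O)=O)cc1` has not yet been measured. Compared with compound 1 it carries a group of 5 heavy atoms (3 carbon, 1 nitrogen, 1 oxygen; no ring) in place of a group of 7 heavy atoms (4 carbon, 1 nitrogen, 1 oxygen, 1 chlorine; no ring), on a double-bonded ring carbon. Going by the values given here, the one measured step, a number 30 percentage points higher from compound 1 to compound 2 (beyond the scatter), only swaps what hangs on the carbonyl carbon; in compound 3 the carbonyl and the amide hydrogen are both gone, so that step does not bear on the change at hand and gives no direction for it. Among the compounds with values here, there is no comparable step in the set, so the expectation for compound 3 rests on compound 1 alone, with a wide range to either side. The expected step is a number 10 percentage points higher from compound 1 to compound 3 (within the scatter). For compound 3 the estimated value in this assay is 30%, within a range from 10% to 55%.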

Compound 3, a percentage reported as activity, at one concentration (the size of the read-out at that concentration, not a potency): 30%
The estimate for compound 3 equals the measured number at the digits printed; the range from low to high includes it.
By their numbers in this assay, from the lowest: compounds 1 and 3 (each within the scatter of the next); then compound 2.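

At the double-bonded ring carbon next to the ring nitrogen, the amide linkage can be exchanged for a group without carbonyl or amide hydrogen, and the reading in this assay stays level with that of the ((2-chloropropyl)carbonyl)amino compound: a number 10 percentage points higher from compound 1 to compound 3 (within the scatter). Set against the phenyl amide, the same group gives a number 20 percentage points lower from compound 2 to compound 3 (beyond the scatter), so compound 2 stands apart from both other compounds, and among these three the amide alone does not go with the higher reading, as compound 1 also carries an amide and stays within the scatter of compound 3. Nothing available on the mechanism or on the properties of these groups accounts for this difference.

From the compounds shown here alone, what remains open is whether the higher reading of compound 2 follows the phenyl ring itself, which a cyclohexyl or a 4-methoxyphenyl group on the same carbonyl would help to separate, and whether a free amine at this ring carbon would read with compound 2 or with compound 1 and compound 3. Each reading also comes from a single concentration, so the relative potency of these compounds remains open.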